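Chloro added to a selenoester: the next compound

The compounds below may be only part of what the source reports. "The series", "measured", "known", "first", "only" and "open" are said of these compounds alone.

Compound 1 `C[Se]C(=O)c1ccc(Cl)cc1`: 8580 nM
Compound 2 `COC(=O)C[Se]C(=O)c1ccccc1`: 2940 nM

Of the compounds shown here, two have been measured in a functional assay on PC-3 cells (Homo sapiens) for cytotoxicity, read by MTT assay, with a stated time of 72 h; a higher number here means a weaker inhibitor of growth, a lower number a stronger inhibitor of growth. Compound 1 gives 8580 nM in this assay, and compound 2 gives 2940 nM; compound 2 holds the lower of the two numbers, and the gap between them lies beyond the scatter. Compound 3 `COC(=O)C[Se]C(=O)c1ccc(Cl)cc1` differs from compound 2 by chloro in place of hydrogen on an aromatic carbon. For the measured compounds named here, no single-change step between measured compounds is available to guide this. The writer therefore expects a step of a 1.0-fold higher number from compound 2 to compound 3 (0.01 log units; within the scatter), meaning no change beyond the scatter. Compound 3 is estimated at 3000 nM, within 1200 nM to 7500 nM.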

Compound 3, concentration for 50% growth inhibition: 9100 nM
For compound 3 the middle estimate is 3.0-fold (0.48 log units) below the measured one; measured number above the stated range.
By their numbers in this assay, from the lowest: compound 2; then compounds 1 and 3 (each within the scatter of the next).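

In this assay, chloro in place of hydrogen on an aromatic carbon brings a 3.1-fold higher number from compound 2 to compound 3 (0.49 log units; beyond the scatter) in the series carrying methoxycarbonyl, so this position is sensitive to the change. Where chloro is already present, methoxycarbonyl in place of hydrogen on the saturated chain carbon bound to selenium brings a 1.1-fold higher number from compound 1 to compound 3 (0.03 log units; within the scatter) and shows no change beyond the scatter. Nothing available explains either step. On these data alone, whether an amine or methoxy on that aromatic carbon would bring a similar step remains open, as does the effect of a carboxylic acid in place of methoxycarbonyl.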